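Chlorine Enters the Benzyl Arm of Compound 3

A few compounds are considered here, and "the series" means these few. Any claim that something is new, unique, unknown or untested is made for them only; others in the source may bear on it.

Compound 3 `CN1CCC[C@@H]1Cn1nc(CCc2ccccc2)c2ccccc2c1=O` is one of three measured members of a shared core. In an assay for binding affinity to Alpha-1B adrenergic receptor (Homo sapiens) (a lower number here means a stronger inhibitor, a higher number a weaker inhibitor), compound 3 gives 200 nM. Compound 1 `CN(C)CCn1nc(Cc2ccc(Cl)cc2)c2ccccc2c1=O` gives 200 nM in this assay, so compound 3 stands level with compound 1 at the digits shown, within the scatter. Compound 2 `COc1cccc(Cc2nn(C[C@H]3CCCN3C)c(=O)c3ccccc23)c1` gives only a limit in this assay, > 1990 nM, and the limit of > 1990 nM in this assay, at which 1 of the 3 values shown sits, marks it as the one limit among the three values. For the measured compounds named here, the single measured step, an at least 9.9-fold lower number from compound 2 to compound 3 (0.99 log units; beyond the scatter), with benzyl in place of 3-methoxyphenyl, bears most directly on the arm now altered. Compound 4 `CN1CCC[C@@H]1Cn1nc(Cc2cccc(Cl)c2)c2ccccc2c1=O` differs from compound 3 by 3-chlorophenyl in place of benzyl on a saturated chain carbon bound to an aromatic carbon. That measured step shows a substituent on this ring can move the number at least modestly, yet compound 1, which also carries a chlorine, matches compound 3. The chlorine here is therefore expected to change the number little, no change at the digits printed from compound 3 to compound 4 (within the scatter). Compound 4 is estimated at 200 nM, with a range from 70 nM to 600 nM.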

Compound 4, inhibition constant: 631 nM
Compound 4: the middle estimate sits 3.2-fold (0.50 log units) below what was measured; measured number outside the range, above it.
By their numbers in this assay, from the lowest: compounds 1 and 3 (each within the scatter of the next); then compound 4. At a limit, above all of these: compound 2.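

In this assay this arm proves responsive to the change: the step reads as a 3.2-fold higher number from compound 3 to compound 4 (0.50 log units; beyond the scatter) and, cut one bond further out, it turns phenethyl into 3-chlorobenzyl, so this single step cannot separate the added chlorine from the shorter chain. Where the chain stays the same, the ring group counts too, since chloro in place of methoxy on an aromatic carbon gives an at least 3.1-fold lower number from compound 2 to compound 4 (0.49 log units; beyond the scatter) and that size rests on a limit for compound 2. Nothing shown here gives a reason for either step.

The compounds shown leave open how an unsubstituted benzyl arm or a 3-chlorophenethyl arm would read on this core, and either would help part chain length from chlorine. From the compounds shown here alone, whether a fluorine, a methyl or an amine on the same ring would track with chlorine also remains open.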